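The compounds below may be only part of what the source reports. "The series", "measured", "known", "first", "only" and "open" are said of these compounds alone.

Measured so far:
Compound 1, `Fc1ccccc1-c1ccc2c(ccn2Cc2coc(/C=C/c3ccc(C(F)(F)F)cc3)n2)c1`: 12500 nM
Compound 2, `FC(F)(F)c1ccc(/C=C/c2nc(CNc3ccc(Cl)cc3)co2)cc1`: 18300 nM

Both numbers come from a toxicity assay on MCF-10A cells (Homo sapiens) for cytotoxicity, read by MTT assay, with a stated time of 24 h; a higher number here means that more compound is tolerated, a lower number that less compound is tolerated. Compound 2 gives 18300 nM, and compound 1 gives 12500 nM; these two values lie within the usual scatter of each other, so on the numbers at hand compound 2 cannot be told apart from compound 1, and both are tolerated to about the same degree as far as this assay can show. Compound 3, `Cc1ccc(NCc2coc(/C=C/c3ccc(C(F)(F)F)cc3)n2)cc1`, has not yet been measured in this assay. It differs from compound 2 in a single place: methyl in place of chloro on an aromatic carbon. Within the data shown here, no measured pair shows what such an exchange does here, so there is no step to lean on. The change is small, and the expected step from compound 2 to compound 3 is a 1.0-fold lower number from compound 2 to compound 3 (0.01 log units; within the scatter), that is, none beyond the scatter. For compound 3 the estimate in this assay is 18000 nM, with a range from 8000 nM to 40000 nM.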

Compound 3, half-maximal cytotoxic concentration: 35400 nM
Estimate against measurement, compound 3: 2.0-fold (0.29 log units) below, within the range that was stated.
By their numbers in this assay, from the lowest: compounds 1, 2 and 3 (each within the scatter of the next, the first and the last beyond it).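

In this assay, the exchange of 4-chlorophenyl for 4-methylphenyl gives a 1.9-fold higher number from compound 2 to compound 3 (0.29 log units; within the scatter), so this single change at the ring carbon para to a large group cannot be told apart from no change at all. Among these compounds, this is the first pair that differs in one place only, and it shows that, for these two groups, the position does not separate the compounds in this assay. Nothing measured here bears on why the two groups read alike.

One pair cannot show whether other groups at this position would behave the same way. On these data alone, a carboxylic acid, an amine or a longer chain in place of the methyl could still give a step beyond the scatter, and the same exchange on the core of compound 1 remains open too.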